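The source may report more compounds than this note shows. Statements on the series, on what has been measured and on what is new or still open speak of the compounds shown alone.

Measured compounds:
- compound 1, `CN1C[C@H](Nc2nc3cc[nH]c3c(=O)n2C)C[C@H](c2cccc(Br)c2)C1`: 7.5 degrees C
- compound 2, `CN1C[C@H](Nc2nc3cc[nH]c3c(=O)n2C)C[C@H](c2ccccc2)C1`: 6.3 degrees C
- compound 3, `C=CCn1c(N[C@@H]2C[C@H](c3ccccc3)CN(C)C2)nc2cc[nH]c2c1=O`: 2.2 degrees C

The read-out throughout is an assay on isolated protein for binding affinity to histone acetyltransferase KAT2B (Homo sapiens), read by fluorescence, tested at 10 uM; a lower number here means that the compound stabilises the target less, a higher number that the compound stabilises the target more against heat. Compound 3 stands lowest of the three values; the nearest is compound 2, and compound 1 lies furthest away, both gaps beyond the scatter.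

Compound 4, `CCn1c(N[C@@H]2C[C@H](c3ccccc3)CN(C)C2)nc2cc[nH]c2c1=O`, has not yet been measured. It differs from compound 3 in one place: methyl in place of vinyl on a saturated chain carbon bound to an aromatic nitrogen. Of the two steps seen so far, only one touches this position: a number 4.1 degrees C lower from compound 2 to compound 3 (beyond the scatter), where a vinyl was added on the same saturated chain carbon bound to the aromatic nitrogen and the shift fell by a large amount. The other step, a number 1.2 degrees C lower from compound 1 to compound 2 (beyond the scatter), concerns the bromo on the aromatic ring and does not bear on the change here. Compound 4 removes the vinyl but keeps a methyl on that carbon, so it sits between compound 2 and compound 3 in what is carried on the aromatic nitrogen. The step from compound 3 to compound 4 is therefore expected to recover part of the loss seen in this assay, as a number 1.6 degrees C higher from compound 3 to compound 4 (beyond the scatter), but not the whole of it. For compound 4 the expected value is 3.8 degrees C, with a range from 1.8 degrees C to 5.8 degrees C.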

Compound 4, shift of the target's melting temperature: 4.8 degrees C
For compound 4 the middle estimate is 1.0 degrees C below the measured one; the range from low to high includes it.
By their numbers in this assay, from the lowest: compound 3; then compound 4; then compound 2; then compound 1.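

In this assay the loss at this position proves graded, not all-or-none: a number 1.5 degrees C lower from compound 2 to compound 4 (beyond the scatter) shows that methyl in place of hydrogen on the saturated chain carbon bound to the aromatic nitrogen already lowers the number, and a number 2.6 degrees C higher from compound 3 to compound 4 (beyond the scatter) shows that methyl in place of vinyl raises it again. Across compound 2, compound 4 and compound 3, the number therefore falls in order from hydrogen to methyl to vinyl on that carbon, with each of these steps beyond the scatter and no compound shown going against this order. The three compounds show this order only and offer no explanation for it, as no measurement bearing on the cause is available.

Allyl and ethyl differ in both length and the double bond. A saturated propyl in place of allyl would be needed to separate those two features. Also open, going by these compounds, are whether a hydroxyl or an amine on that chain fits the same order and whether the bromo seen in compound 1 changes the number in the same way when ethyl replaces the smaller group on the aromatic nitrogen.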